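From pyridin-2-yl to pyridin-3-yl in compound 3

The source may hold more compounds than are shown below. What is called first, only, known or untested is meant among the compounds shown, and "the series" means these compounds.

Of the compounds shown here, two have so far been tested in a functional assay on renal cells (Homo sapiens) for antiproliferative activity; a higher number here means a weaker inhibitor of growth, a lower number a stronger inhibitor of growth. There, compound 1 (`Cc1cn2c(/C=N/NC(=N)N)c(-c3cccnc3)nc2s1`) gives 9550 nM, and compound 2 (`N=C(N)N/N=C/c1c(-c2ccccn2)nc2sc(Cl)cn12`) gives 7940 nM. These two values lie within the usual scatter of each other, so compound 2 stands level with compound 1 and the numbers do not separate them.

Compound 3 (`N=C(N)N/N=C/c1c(-c2cccnc2)nc2sc(Cl)cn12`) contains the same atoms as compound 2, joined differently: pyridin-3-yl takes the place of pyridin-2-yl on an aromatic carbon of the shared core (pyridin-3-yl in place of pyridin-2-yl on an aromatic carbon). Going by the values given here, no two tested compounds differ in one place only, so the data offer no direct measure of such an exchange. Compound 1 already bears pyridin-3-yl and gives 9550 nM, although it differs from compound 3 elsewhere on the core. On that limited evidence, no step beyond the scatter is expected in this assay. The expected change is small, with an estimated 1.1-fold lower number from compound 2 to compound 3 (0.05 log units; within the scatter). Compound 3 is expected at 7000 nM, with an estimated range from 2500 nM to 20000 nM.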

Compound 3, concentration for 50% growth inhibition: 18200 nM
Compound 3: middle estimate off by 2.6-fold (0.41 log units), on the low side, within the range that was stated.
By their numbers in this assay, from the lowest: compounds 2, 1 and 3 (each within the scatter of the next, the first and the last beyond it).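

Going by these compounds alone, the exchange of pyridin-2-yl for pyridin-3-yl on the aromatic carbon of the five-membered aromatic ring gives the first measured one-place step at this position in this assay, with a 2.3-fold higher number from compound 2 to compound 3 (0.36 log units; beyond the scatter), a modest step that shows that the attachment of the pyridine ring is not indifferent here, even though the atoms stay the same. With pyridin-3-yl held constant, chloro in place of methyl on an aromatic carbon gives a 1.9-fold higher number from compound 1 to compound 3 (0.28 log units; within the scatter), so this second exchange does not separate its two compounds, and the numbers show no effect from it. Nothing measured here accounts for the size of the pyridine step.

The compounds shown leave open how pyridin-4-yl or a plain phenyl ring would stand at this place, and whether the step seen with chloro on the core would recur with methyl there. They also leave open what an amine or a methoxy group would do in place of chloro or methyl on the shared core.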